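Swapping the amide ring on a methylated side chain

This account rests on a few compounds, and the source may have more. Where it says the series, first, only, none or still open, it means among the compounds named here.

In a functional assay on PC-3 cells (Homo sapiens) for inhibition, read by sulforhodamine B assay, with a stated time of 72 h (on this read-out lower numbers stand for stronger inhibition of growth and higher numbers for weaker inhibition of growth), compound 1 `COc1ncc(-c2ccc3nccc(/C(C)=C/C(=O)N4CCN(C)CC4)c3c2)cc1NS(=O)(=O)c1ccc(F)cc1F` gives 360 nM and compound 2 `COc1ncc(-c2ccc3nccc(/C=C/C(=O)N4CCN(C)CC4)c3c2)cc1NS(=O)(=O)c1ccc(F)cc1F` gives 450 nM. For the measured compounds named here, these two values lie within the usual scatter of each other, so compound 2 stands level with the only other measured compound. Compound 3 `COc1ncc(-c2ccc3nccc(/C(C)=C\C(=O)N4CCOCC4)c3c2)cc1NS(=O)(=O)c1ccc(F)cc1F` carries 1-methyl-2-((morpholin-4-yl)carbonyl)ethenyl in place of 2-((4-methylpiperazin-1-yl)carbonyl)ethenyl on an aromatic carbon. Only the methyl part of this change has a measured counterpart: a 1.3-fold higher number from compound 1 to compound 2 (0.10 log units; within the scatter). Going by the values given here, no measured pair shows what exchanging the ring does, so that part remains open. In this assay, no shift beyond the scatter is therefore expected, and the estimated move is a 1.3-fold higher number from compound 2 to compound 3 (0.12 log units; within the scatter). Compound 3 is estimated at 600 nM, with an expected range of 150 nM to 2500 nM, kept wide for the untested ring exchange.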

Compound 3, concentration for 50% growth inhibition: 8020 nM
Compound 3: the middle estimate sits 13-fold (1.13 log units) below what was measured, and the stated range ends below it.
By their numbers in this assay, from the lowest: compounds 1 and 2 (each within the scatter of the next); then compound 3.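

The side chain on this aromatic carbon, opposite the ring nitrogen, is far less forgiving than the first two compounds suggested: in this assay the methyl step stayed within the scatter, whereas the change to the morpholine amide gives a 22-fold higher number from compound 1 to compound 3 (1.35 log units; beyond the scatter) and, with the methyl also present, an 18-fold higher number from compound 2 to compound 3 (1.25 log units; beyond the scatter). Growth inhibition therefore weakens sharply in compound 3, even though the entering group keeps a six-membered non-aromatic ring with 2 hetero atoms and, compared with the group in compound 2, the same count of heavy atoms. Nothing measured here gives a reason for this loss.

The double bond is also drawn with the other geometry in compound 3, so the effects of the ring and of that geometry cannot be separated. As far as these compounds go, whether a piperidine amide or an open-chain dimethylamino amide would stay close to compound 1 or fall towards compound 3 also remains open.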